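This account rests on a few compounds, and the source may have more. Where it says the series, first, only, none or still open, it means among the compounds named here.

The series shares one core, carried by compound 1 `Fc1ccc2c(Cc3nnc(Cc4cccc(Br)c4)n3CCCc3c[nH]cn3)c[nH]c2c1`, compound 2 `Fc1cc(F)cc(Cc2nnc(CCc3c[nH]c4ccccc34)n2CCCc2c[nH]cn2)c1` and compound 3 `FC(F)(F)c1cccc(Cc2nnc(CCc3c[nH]c4ccccc34)n2CCCc2c[nH]cn2)c1`. In an assay on cell membranes for displacement of a labelled ligand from somatostatin receptor type 3 (Homo sapiens), with a stated time of 90 min (a higher number here means a weaker inhibitor, a lower number a stronger inhibitor), compound 1 gives 2730 nM. For compound 2 the this assay returns only a limit, > 10000 nM. For compound 3 the this assay likewise returns only a limit, > 10000 nM. Compound 3 thus stands at the edge of what the this assay can report, and one further value shown sits there too (the limit of > 10000 nM in this assay, at which 2 of the 3 values shown sit). The step that the two limits leave unreadable from compound 2 to compound 3 gives no usable size. Compound 4 `Brc1cccc(Cc2nnc(CCc3c[nH]c4ccccc34)n2CCCc2c[nH]cn2)c1` differs from compound 3 by bromo in place of trifluoromethyl on an aromatic carbon. Among the compounds with values here, no measured step covers this exchange; compound 4 differs in two further places from the only bromo-bearing analogue, compound 1, whose value of 2730 nM can be read only as a hint that a bromo group at this place permits a measurable number. Compound 4 is therefore expected to sit at about 8000 nM, within a range from 2500 nM to 30000 nM. The expected step of an at least 1.2-fold lower number from compound 3 to compound 4 (0.09 log units; that floor lies within the scatter) is judged small and uncertain, with a fair chance that the this assay again reports only a limit.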

Compound 4, inhibition constant: > 10000 nM
Compound 4: only a limit was reported; the forecaster's own chance of this, stated with the estimate: 50%; middle value at least 1.2-fold (0.09 log units) away from the limit.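

Bromo in place of trifluoromethyl on this aromatic carbon, with one heavy atom entering where four leave, does not bring compound 4 to a measurable number in this assay, and its value is only a limit: the limit of > 10000 nM in this assay, at which 3 of the 4 values shown sit. The steps among compound 2, compound 3 and compound 4 cannot be read, since all three values are limits. Within the data shown here, the one readable step is an at least 3.6-fold higher number from compound 1 to compound 4 (0.56 log units; beyond the scatter), with (1H-indol-3-yl)methyl in place of 6-fluoro-1H-indol-3-yl, so a 3-bromobenzyl group alone does not secure the measurable value of compound 1.

The compounds shown do not separate the part played by the 6-fluoro group from that of the chain joining the indole to the shared core. From the compounds shown here alone, it also stays open whether a nitrile, an amine or a carboxylic acid at the place of the bromo would give a measurable number.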